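Swapping a Nitro for a Fluoro

A few compounds are considered here, and "the series" means these few. Any claim that something is new, unique, unknown or untested is made for them only; others in the source may bear on it.

- Compound 1 `Nc1nc(N)c(CCCNc2cc(F)ccc2[N+](=O)[O-])c(O)n1` gives > 100000 nM as a limit of the assay
- Compound 2 `COC(=O)c1ccc(CN(CCCc2c(N)nc(N)nc2O)c2cc(F)c(F)cc2[N+](=O)[O-])cc1` gives 55000 nM
- Compound 3 `Nc1nc(N)c(CCCNc2cc(F)c([N+](=O)[O-])cc2[N+](=O)[O-])c(O)n1` gives 1100 nM

These values come from a functional assay on CCRF-CEM cells (Homo sapiens) for cytotoxicity, in the absence of a further agent (on this read-out higher numbers stand for weaker inhibition and lower numbers for stronger inhibition), where compound 3 (1100 nM) holds the lowest number and compound 2 (55000 nM) a much higher one. Compound 4 `Nc1nc(N)c(CCCNc2cc(F)c(F)cc2[N+](=O)[O-])c(O)n1` differs from compound 3 by fluoro in place of nitro on an aromatic carbon. For the measured compounds named here, one measured step bears on this: nitro in place of hydrogen gave the large change an at least 90-fold lower number from compound 1 to compound 3 (1.95 log units; beyond the scatter) and that same nitro leaves here. A large rise is therefore expected in this assay, perhaps smaller than that step, since fluoro rather than hydrogen enters. The expected step is a 23-fold higher number from compound 3 to compound 4 (1.36 log units; beyond the scatter) as an estimate. Compound 4 is therefore estimated at 25000 nM (range 6000 nM to 100000 nM).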

Compound 4, half-maximal inhibitory concentration: > 100000 nM
Compound 4: a limit, no number; the forecaster's own chance of this, stated with the estimate: 20%; middle value at least 4.0-fold (0.60 log units) away from the limit.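

Fluoro does not stand in for nitro at this position, para to a large group: the change gives an at least 90-fold higher number from compound 3 to compound 4 (1.95 log units; beyond the scatter). In this assay compound 4 gives > 100000 nM, a limit of the assay and not a number, so this step is only a floor. Hydrogen in place of 4-(methoxycarbonyl)benzyl gives an at least 1.8-fold higher number from compound 2 to compound 4 (0.25 log units; that floor lies within the scatter), and the step between the two compounds that both sit at the limit cannot be read, because neither value is a number: the limit of > 100000 nM in this assay, at which 2 of the 4 values shown sit.

As far as these compounds go, whether a nitrile or a carboxylic acid at this position would keep a number as low as that of compound 3 stays open. From the compounds shown here alone, how far compound 4 lies beyond the limit also stays open.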